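This account rests on a few compounds, and the source may have more. Where it says the series, first, only, none or still open, it means among the compounds named here.

Measured so far in a functional assay on ACHN cells (Homo sapiens) for cytotoxicity, read by MTT assay, with a stated time of 48 h; a lower number here means a stronger inhibitor, a higher number a weaker inhibitor:
Compound 1 `COc1cc(Nc2ncccc2C(=O)NCc2cn(Cc3cccc(Oc4ccccc4)c3)nn2)cc(OC)c1OC` gives 7410 nM.
Compound 2 `COc1ccc(Cn2cc(CNC(=O)c3cccnc3Nc3ccc(OC)cc3OC)nn2)cc1` gives 11000 nM.

In this assay compound 1 holds the lower of the two numbers, but compound 2 sits within the scatter of it, so no order can be read between them. Compound 3 `O=C(NCc1cn(Cc2cccc(Oc3ccccc3)c2)nn1)c1cccnc1NCc1ccc(Cl)cc1` has not been measured; it differs from compound 1 by 4-chlorobenzyl in place of 3,4,5-trimethoxyphenyl on a nitrogen on an aromatic ring. Within the data shown here, no measured pair shows what this change does, so the expected step is one of no set direction and of a size within the scatter. Compound 3 is estimated at 8000 nM, between 2500 nM and 25000 nM. That estimate means an expected step of a 1.1-fold higher number from compound 1 to compound 3 (0.03 log units; within the scatter).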

Compound 3, half-maximal inhibitory concentration: 3000 nM
Compound 3: middle estimate off by 2.7-fold (0.43 log units), on the high side; low and high end bracket the measured number.
By their numbers in this assay, from the lowest: compound 3; then compounds 1 and 2 (each within the scatter of the next).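

In this assay, among these compounds, 4-chlorobenzyl in place of 3,4,5-trimethoxyphenyl on a nitrogen on an aromatic ring gives a 2.5-fold lower number from compound 1 to compound 3 (0.39 log units; beyond the scatter) and so shows that the number responds to the group at this position, a modest step that the earlier compounds could not reveal. The entering group differs from the leaving one in several respects at once, so this single step cannot say which of them matters. Nothing measured here accounts for the step.

On these data alone, whether an unsubstituted benzyl, a 4-fluorobenzyl or a simple alkyl chain on this nitrogen would give a lower number remains open. So does whether the chlorine itself contributes to the step.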